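The source may report more compounds than this note shows. Statements on the series, on what has been measured and on what is new or still open speak of the compounds shown alone.

Of the compounds shown here, two around a shared core have been measured. Compound 1 `COc1ccc(N2C[C@@H](C)N[C@@H](C)C2)cc1NS(=O)(=O)c1ccc(N2CCCC2=O)cc1` gives 39.8 nM in a functional assay for agonist activity at growth hormone secretagogue receptor type 1 (Homo sapiens), read by FLIPR; a higher number here means that more compound is needed for the effect, a lower number that less compound is needed. Going by the values given here, compound 2 `COc1ccc(N2C[C@@H](C)N[C@@H](C)C2)cc1NS(=O)(=O)c1ccc(-c2cccs2)cc1` gives 3.98 nM, the lowest of the two numbers so far; its nearest neighbour is compound 1, and the single step between them, a 10-fold lower number from compound 1 to compound 2 (1.00 log units; beyond the scatter), lies beyond the scatter.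

Compound 3 `COc1ccc(N2C[C@@H](C)N[C@@H](C)C2)cc1NS(=O)(=O)c1ccc(-c2ccc(C)o2)cc1` differs from compound 2 in one place: 5-methylfuran-2-yl in place of thiophen-2-yl on an aromatic carbon. Among the compounds with values here, no measured step swaps one five-membered aromatic ring with one hetero atom for another; the only step available replaced a 2-oxopyrrolidin-1-yl by a thiophen-2-yl, which is a different kind of change. The change from compound 2 to compound 3 is therefore expected to give a step of a 1.3-fold higher number from compound 2 to compound 3 (0.10 log units; within the scatter), not beyond the scatter. Compound 3 is estimated at 5 nM, within a range from 2 nM to 15 nM.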

Compound 3, half-maximal effective concentration: 0.794 nM
Estimate against measurement, compound 3: 6.3-fold (0.80 log units) above, and the stated range ends above it.
By their numbers in this assay, from the lowest: compound 3; then compound 2; then compound 1.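

In this assay, placing 5-methylfuran-2-yl where thiophen-2-yl stood gives a 5.0-fold lower number from compound 2 to compound 3 (0.70 log units; beyond the scatter), so this site, on an aromatic carbon and para to a large group, still responds when one five-membered aromatic ring with one hetero atom replaces another, a kind of swap the earlier pair did not test. Measured against the 2-oxopyrrolidin-1-yl group, the same ring gives a 50-fold lower number from compound 1 to compound 3 (1.70 log units; beyond the scatter), a step rated large, where thiophen-2-yl gave only a modest one. No data are available that bear on the cause of these steps.

This swap changes the ring's hetero atom from sulfur to oxygen and adds a methyl group in one move, so the two changes cannot be told apart. A plain furan-2-yl or a 5-methylthiophen-2-yl would separate them, and an ethyl group in place of the methyl would show whether a longer chain is tolerated.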